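The source may hold more compounds than are shown below. What is called first, only, known or untested is meant among the compounds shown, and "the series" means these compounds.

In an assay on isolated protein for inhibition of protein kinase C zeta type (Homo sapiens), read by mobility shift assay, tested at 30 uM (on this read-out lower numbers stand for less inhibition and higher numbers for more inhibition at the one concentration tested (going by the name of the read-out)), compound 2 `COCCNc1nc(-c2ccccc2)cc2c1c(N)nn2C` gives 20%. Compound 1 `COCCNc1nc(C)cc2c1c(N)nn2C` carries the change (methyl in place of phenyl on an aromatic carbon), and in this assay compound 1 gives -10%, so that a number 30 percentage points lower from compound 2 to compound 1 (beyond the scatter). Compound 3 `Cc1cc2nc(-c3ccccc3)nc(N)c2c(=O)[nH]1` rests on a different core; the difference between its core and that of compound 2 is not broken down here. In this assay compound 3 gives -17%. Compound 4 `Cc1nc(N)c2c(=O)[nH]c(C)cc2n1` is derived from compound 3 by the change (methyl in place of phenyl on an aromatic carbon). Within the data shown here, this is the same kind of change as the one from compound 2 to compound 1, but not the same: in compound 1 the methyl sits on a six-membered aromatic ring with 1 nitrogen, next to the ring nitrogen and meta to a (2-methoxyethyl)amino group, whereas in compound 4 it sits on a six-membered aromatic ring with 2 nitrogen, between two ring nitrogen atoms and meta to an amino group. Because compound 3 already gives -17%, the step is expected to be a number 3 percentage points lower from compound 3 to compound 4 (within the scatter), smaller than the earlier one. Compound 4 is therefore estimated at -20%, between -40% and 0%.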

Compound 4, a percentage reported as inhibition, at one concentration (the size of the read-out at that concentration, not a potency): 3%
Estimate against measurement, compound 4: 23 percentage points below, outside the stated range (above it).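

The swap of phenyl for methyl does not carry over unchanged from one core to the other in this assay: the same change on two cores in this assay, a number 30 percentage points lower (beyond the scatter) from compound 2 to compound 1 and a number 20 percentage points higher (beyond the scatter) from compound 3 to compound 4, 50 percentage points apart, beyond the scatter of two such steps. On the core of compound 3, the swap gives a number 20 percentage points higher from compound 3 to compound 4 (beyond the scatter), so its direction here is the opposite of that seen on the other core. Among these compounds, this shows that a step measured on one core was a poor guide to the step on the other in this pair of cores, but it does not show which structural difference between the cores is responsible, and with only two pairs it sets no rule for any further core; these are also readings at a single concentration, not potencies.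

The compounds shown leave open how other groups on that aromatic carbon, such as an ethyl group, a longer alkyl chain or an amine, would behave on each core. They also leave open whether a carboxylic acid there would follow either of the two steps seen so far.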